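Methyl for dimethylcarbamoyl on the pyrazole of compound 2

The source may hold more compounds than are shown below. What is called first, only, known or untested is meant among the compounds shown, and "the series" means these compounds.

Compound 1, `CCC(Oc1ccc(-n2cc(C(F)(F)F)cn2)cc1)c1ccc(C(=O)NCCC(=O)O)cc1`, gives 1.9.
Compound 2, `CCCC(Oc1ccc(-n2cc(C(=O)N(C)C)cn2)cc1)c1ccc(C(=O)NCCC(=O)O)cc1`, gives 0.5.
Compound 3, `CCCC(Oc1cnc(-n2cc(C(F)(F)F)cn2)nc1)c1ccc(C(=O)NCCC(=O)O)cc1`, gives 1.5.

These three numbers come from a physicochemical assay for lipophilicity, using the shake flask method, at pH 7.4; a higher number here means a more lipophilic compound, a lower number a more polar compound. Compound 2 stands lowest of the three: compound 3 lies higher, and compound 1 lies higher still, both gaps beyond the scatter. For the measured compounds named here, compound 1 and compound 3 both carry a trifluoromethyl on the pyrazole, whereas compound 2 carries a dimethylcarbamoyl there, and compound 2 is the only one with an acceptor-bearing group at that spot.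

The unmeasured compound 4, `CCCC(Oc1ccc(-n2cc(C)cn2)cc1)c1ccc(C(=O)NCCC(=O)O)cc1`, shares the core of compound 2 and differs from it in one place: methyl in place of dimethylcarbamoyl on an aromatic carbon. Going by the values given here, no such step between two measured compounds exists here, so the size can only be expected, not read off. In this assay the expected step is a number 1.20 log units higher from compound 2 to compound 4 (beyond the scatter), a rise beyond the scatter, because compound 1 gives 1.9 and compound 3 gives 1.5 with groups lacking an acceptor at that spot. Compound 4 is therefore estimated at 1.7, with a range from 1.2 to 2.2.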

Compound 4, distribution coefficient: 2.1
For compound 4 the middle estimate is 0.40 log units below the measured one; the measured number falls inside the stated range.
By their numbers in this assay, from the lowest: compound 2; then compound 3; then compounds 1 and 4 (each within the scatter of the next).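

In this assay, replacing dimethylcarbamoyl with methyl on an aromatic carbon of the five-membered aromatic ring with 2 nitrogen gives a number 1.60 log units higher from compound 2 to compound 4 (beyond the scatter), a large step. For the compounds shown here, this is the first direct reading of a change at this position with the rest of the structure held constant, and it shows that this one place can by itself shift the reading well beyond the scatter; the earlier compounds could not show this, since no two of them differed in one place only. The change removes a group of 5 heavy atoms that has 1 hydrogen-bond acceptor and puts in a single carbon, but nothing shown here accounts for the size of the step.

With size and acceptor count changing together, this single pair cannot separate the two, and a nitrile, a primary carboxamide or an ethyl group at this position would be needed to tell them apart. From the compounds shown here alone, it also remains open whether the same exchange gives a step of similar size on the cores of compound 1 and compound 3.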